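Swapping the hydroxyethyl for an ethynyl on compound 2

The compounds below may be only part of what the source reports. "The series", "measured", "known", "first", "only" and "open" are said of these compounds alone.

In an assay on isolated protein for inhibition of Retinaldehyde dehydrogenase 3 (Homo sapiens) (a higher number here means a weaker inhibitor, a lower number a stronger inhibitor), compound 1 `Cn1ncc2c(=O)n(-c3ccccc3)c(COc3cccc(F)c3)nc21` gives 780 nM. Compound 2 `CC(Sc1nc2c(cnn2C)c(=O)n1-c1ccc(CCO)cc1)c1ccccc1` in this assay gives 3000 nM, the higher of the two numbers, and its gap to compound 1 is beyond the scatter. Among the measured compounds shown here, the two compounds differ in several places, so no single step connects them. Compound 3 `C#Cc1ccc(-n2c(SC(C)c3ccccc3)nc3c(cnn3C)c2=O)cc1` differs from compound 2 in one place: ethynyl in place of 2-hydroxyethyl on an aromatic carbon. For the measured compounds named here, no measured pair shows this change, so for compound 3 a step of a 1.2-fold lower number from compound 2 to compound 3 (0.08 log units; within the scatter) is expected, not beyond the scatter in either direction. Compound 3 is estimated at 2500 nM, between 1000 nM and 7000 nM.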

Compound 3, half-maximal inhibitory concentration: 520 nM
The estimate for compound 3 lay 4.8-fold (0.68 log units) above the measured number, outside the stated range (below it).
By their numbers in this assay, from the lowest: compounds 3 and 1 (each within the scatter of the next); then compound 2.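

At this position, para to a large group, the substituent matters: in this assay, ethynyl in place of 2-hydroxyethyl gives a 5.8-fold lower number from compound 2 to compound 3 (0.76 log units; beyond the scatter). A hydrogen-bond donor and acceptor on this side chain are therefore not needed for a lower number, since ethynyl has neither. Nothing at hand gives a reason for the step.

Open, from the compounds shown here alone, is whether an amine, a carboxylic acid or a longer chain ending in a triple bond at this position would shift the number further. Also open, going by these compounds, is whether ethynyl gives a similar step on compound 1.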